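Mesityl for phenyl on the chain carbon

The compounds below may be only part of what the source reports. "The series", "measured", "known", "first", "only" and "open" are said of these compounds alone.

Measured compounds:
compound 1 `O=C(CC(c1ccccc1)C(C(=O)Nc1ccccn1)C(=O)Nc1ccccn1)c1ccccc1`, 28100 nM
compound 2 `O=C(CC(c1cccs1)C(C(=O)Nc1ccccn1)C(=O)Nc1ccccn1)c1ccccc1`, "not active" (no number reported) (no number reported)

Within the data shown here, in a functional assay on HeLa cells (Homo sapiens) for inhibition, read by MTT assay, with a stated time of 48 h (on this read-out lower numbers stand for stronger inhibition and higher numbers for weaker inhibition), compound 1 gives 28100 nM, the only number in the set. In this assay compound 2 is recorded as "not active" (no number reported) without a number. Compound 3 `Cc1cc(C)c(C(CC(=O)c2ccccc2)C(C(=O)Nc2ccccn2)C(=O)Nc2ccccn2)c(C)c1` is not yet measured; it differs from compound 1 by 2,4,6-trimethylphenyl in place of phenyl on a saturated chain carbon bound to two saturated chain carbons. Among the measured compounds shown here, no measured pair isolates this change, so the step in this assay is expected to stay within scatter. For compound 3 the estimate is 35000 nM, range 10000 nM to 150000 nM, meaning an expected step of a 1.2-fold higher number from compound 1 to compound 3 (0.10 log units; within the scatter).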

Compound 3, half-maximal inhibitory concentration: 15100 nM
Beside the measured number, compound 3's estimate is 2.3-fold (0.37 log units) above it, and the stated range covers the measured number.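

In this assay 2,4,6-trimethylphenyl in place of phenyl on a saturated chain carbon bound to two saturated chain carbons gives a 1.9-fold lower number from compound 1 to compound 3 (0.27 log units; within the scatter) and leaves the two compounds indistinguishable. This position therefore takes an aryl group of 9 heavy atoms in place of one of 6 and still yields a measurable number, with no step beyond the scatter. Nothing measured here accounts for this result.

Going by these compounds, whether an amine, a carboxylic acid or a longer chain at this carbon would give a number clearly apart from that of compound 1 remains open.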